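This account rests on a few compounds, and the source may have more. Where it says the series, first, only, none or still open, it means among the compounds named here.

Measured in a physicochemical assay for solubility; a higher number here means a more soluble compound, a lower number a less soluble compound:
Compound 1 `CNC(=O)c1cc(C(=O)NC2CCC2)cn(Cc2ccncc2)c1=O`: >= 118 ug/mL.
Compound 2 `CNC(=O)c1cc(C(=O)NC2CC2)cn(CC2CCCOC2)c1=O`: >= 131 ug/mL.
Compound 3 `CNC(=O)c1cc(C(=O)NC2CCOCC2)cn(Cc2ccccc2)c1=O`: >= 174 ug/mL.

Every one of these three values is a limit of this assay, not a number. Compound 2 stands at the limit of >= 131 ug/mL in this assay, at which 1 of the 3 values shown sits. The two further values shown are limits as well, so no order among the three compounds can be read from them. Compound 4 `CNC(=O)c1cc(C(=O)NC2CC2)cn(Cc2cccc(C#N)c2)c1=O` has not been measured; it differs from compound 2 by 3-cyanophenyl in place of oxan-3-yl on a saturated chain carbon bound to an aromatic nitrogen. Going by the values given here, no step between measured compounds covers this change, so its size can only be expected. A downward step in this assay, likely beyond the scatter, is expected: an at least 2.3-fold lower number from compound 2 to compound 4 (0.37 log units; beyond the scatter). Compound 4 is estimated at 55 ug/mL in this assay, within a range of 18 ug/mL to 150 ug/mL.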

Compound 4, solubility: >= 148 ug/mL
Compound 4: only a limit was reported; the forecaster's own chance of this, stated with the estimate: 30%; middle value at least 2.6-fold (0.42 log units) from the limit.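

In this assay, compound 2 and compound 4 both carry only limits, so no step can be read between them. On these data alone, whether 3-cyanophenyl in place of oxan-3-yl changes this read-out at all, and in which direction, stays open.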